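A few compounds are considered here, and "the series" means these few. Any claim that something is new, unique, unknown or untested is made for them only; others in the source may bear on it.

Compound 1 `CC(C)[C@H](NC(=O)[C@]1(Cc2ccccc2)CCN1C(=O)OCc1ccccc1)C(N)=O`, compound 2 `C[C@H](NC(=O)[C@@]1(Cc2ccccc2)CCN1C(=O)OCc1ccccc1)C(=O)N(C)C` and compound 3 `C[C@H](NC(=O)[C@]1(Cc2ccccc2)CCN1C(=O)OCc1ccccc1)C(=O)NC1CCCCC1` share one core and differ only in the group carried on an amide-type nitrogen. All three were tested in an ADME assay on HELF cells (Homo sapiens) for cytotoxicity, with a stated time of 3 days; a lower number here means that less compound is tolerated, a higher number that more compound is tolerated. In this assay compound 1 gives no number but only the limit of the assay, > 100000 nM. Compound 2 likewise reaches only a limit in this assay, > 100000 nM. Compound 3 also stops at a limit, > 100000 nM. For the measured compounds named here, compound 2 therefore stands exactly where every value so far stands, namely at the limit of > 100000 nM in this assay, at which 3 of the 3 values shown sit. Going by the values given here, the one step between measured compounds that differ in a single place is a step that the two limits leave unreadable from compound 1 to compound 3. Both of its ends are limits, so its size cannot be read. Compound 4 `CC(C)C[C@H](NC(=O)[C@@]1(Cc2ccccc2)CCN1C(=O)OCc1ccccc1)C(N)=O` has not yet been tested; it differs from compound 2 in one place: 1-carbamoyl-3-methylbutyl in place of 1-(dimethylcarbamoyl)ethyl on an amide-type nitrogen. The exchanged group sits on the same amide-type nitrogen as the exchanged groups of compound 1 and compound 3, and those exchanges left every compound at the limit, so the step from compound 2 to compound 4 is expected to be none beyond the scatter, a number no higher from compound 2 to compound 4 (the limit leaves the size open), with the assay most likely again reporting only a limit. For compound 4 the expected value in this assay is 100000 nM, within a range from 40000 nM to 100000 nM.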

Compound 4, minimum cytotoxic concentration: > 100000 nM
Compound 4: a limit, no number (the forecaster's own chance of this, stated with the estimate: 85%); the middle value sits exactly at the limit.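

In this assay compound 4 reaches only a limit, > 100000 nM, so, with compound 2 also at a limit, no step can be read between the two. The compounds shown leave open the minimum cytotoxic concentration of each and whether the group on the amide-type nitrogen affects it, since all values sit together: the limit of > 100000 nM in this assay, at which 4 of the 4 values shown sit.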